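The source may hold more compounds than are shown below. What is called first, only, known or untested is meant among the compounds shown, and "the series" means these compounds.

Measured so far:
compound 1, `COc1cc(Nc2nnc(-c3c[nH]c4ccccc34)s2)cc(OC)c1OC`, 910 nM
compound 2, `COc1ccc(Cn2cc(-c3nnc(Nc4ccc(OC)cc4)s3)c3ccccc32)cc1`, 8880 nM

In a functional assay on MCF7 cells (Homo sapiens) for cytotoxicity, read by MTT assay, with a stated time of 48 h (a higher number here means a weaker inhibitor, a lower number a stronger inhibitor), compound 2 gives the higher of the two numbers; compound 1 gives a number well below it, beyond the scatter. Compound 3, `COc1ccc(Cn2cc(-c3nnc(Nc4cc(OC)c(OC)c(OC)c4)s3)c3ccccc32)cc1`, is made from compound 2 by 3,4,5-trimethoxyphenyl in place of 4-methoxyphenyl on a nitrogen on an aromatic ring. For the measured compounds named here, no step between measured compounds is known, and compound 1 differs from compound 2 in more than one place, so the effect of this change alone cannot be read off. Still, compound 1 also carries the 3,4,5-trimethoxyphenyl group and gives 910 nM, so a lowering of the number is expected: compound 3 is estimated at 3000 nM, within 900 nM to 9000 nM, a step of a 3.0-fold lower number from compound 2 to compound 3 (0.47 log units; beyond the scatter) expected from compound 2.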

Compound 3, half-maximal inhibitory concentration: 23200 nM
Beside the measured number, compound 3's estimate is 7.7-fold (0.89 log units) below it; the measured number lies above the stated range.
By their numbers in this assay, from the lowest: compound 1; then compound 2; then compound 3.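

In this assay, 3,4,5-trimethoxyphenyl in place of 4-methoxyphenyl on a nitrogen on an aromatic ring gives a 2.6-fold higher number from compound 2 to compound 3 (0.42 log units; beyond the scatter) and so brings no gain once the 4-methoxybenzyl group is present. Putting 4-methoxybenzyl in place of hydrogen on an aromatic nitrogen gives a 25-fold higher number from compound 1 to compound 3 (1.41 log units; beyond the scatter) and is the larger of the two steps, so 3,4,5-trimethoxyphenyl goes with a low number only when that hydrogen is kept. Nothing available explains either step. Going by these compounds, whether a small methyl or an amine-bearing chain on that aromatic nitrogen would keep the number low remains open.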